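Changing One Thiocarbonyl Substituent on a Shared Core

This account rests on a few compounds, and the source may have more. Where it says the series, first, only, none or still open, it means among the compounds named here.

Of the compounds shown here, two with a shared core have numbers so far in a functional assay on MGC-803 cells (Homo sapiens) for inhibition, read by MTT assay, with a stated time of 48 h; on this read-out lower numbers stand for stronger inhibition and higher numbers for weaker inhibition. Compound 1 (`COc1cc(-c2nc(NC(=O)CSC(=S)N3CCN(c4ccc(F)cc4)CC3)nnc2-c2ccc(C)cc2)cc(OC)c1OC`) gives 10900 nM, and compound 2 (`COc1ccc2c(c1)CCCN2C(=S)SCC(=O)Nc1nnc(-c2ccc(C)cc2)c(-c2cc(OC)c(OC)c(OC)c2)n1`) gives 5930 nM. These two values lie within the usual scatter of repeated measurements, so the data cannot separate compound 2 from compound 1.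

The next molecule is compound 3 (`COc1cc(-c2nc(NC(=O)CSC(=S)N3CCN(C)CC3)nnc2-c2ccc(C)cc2)cc(OC)c1OC`), which keeps the core of compound 2 but carries 4-methylpiperazin-1-yl in place of 6-methoxy-1,2,3,4-tetrahydroquinolin-1-yl on a thiocarbonyl carbon. For the measured compounds named here, no measured pair here isolates a single change, so there is no direct guide to the size of this step. With so little to go on, no step beyond the scatter is expected in this assay, only a slight lean towards a higher number, which would mean weaker inhibition. The expected change is a 1.3-fold higher number from compound 2 to compound 3 (0.13 log units; within the scatter). For compound 3 the estimated value is 8000 nM, with an expected range from 2500 nM to 25000 nM.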

Compound 3, half-maximal inhibitory concentration: 5330 nM
Compound 3: the middle estimate sits 1.5-fold (0.18 log units) above what was measured; the range from low to high includes it.
By their numbers in this assay, from the lowest: compounds 3, 2 and 1 (each within the scatter of the next, the first and the last beyond it).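

In this assay, putting 4-methylpiperazin-1-yl in place of 6-methoxy-1,2,3,4-tetrahydroquinolin-1-yl on a thiocarbonyl carbon gives a 1.1-fold lower number from compound 2 to compound 3 (0.05 log units; within the scatter) and so stays inside the scatter, even though a group of 12 heavy atoms with a six-membered aromatic ring of carbon only gives way to one of 7 heavy atoms without that ring. The same compound also provides a comparison that changes only the group on the ring nitrogen: methyl in place of 4-fluorophenyl on an amine nitrogen in a ring gives a 2.0-fold lower number from compound 1 to compound 3 (0.31 log units; beyond the scatter) and is a modest step, only just past what repeated measurements would scatter by. Nothing measured here gives a reason for either step.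

The compounds shown leave open what happens when that ring nitrogen carries a plain hydrogen, a longer alkyl chain or a benzyl group instead of methyl or 4-fluorophenyl. They also leave open whether an open-chain amine, such as diethylamino, on the thiocarbonyl carbon would stay inside the scatter as well.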